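The source may report more compounds than this note shows. Statements on the series, on what has been measured and on what is new or still open speak of the compounds shown alone.

Values in a toxicity assay on MCF-10A cells (Homo sapiens) for inhibition, read by MTT assay, with a stated time of 72 h (a lower number here means a stronger inhibitor of growth, a higher number a weaker inhibitor of growth), for the measured members of the series:
compound 1 `O=S(=O)(NCCCNCc1cccc2ccccc12)c1cc(C(F)(F)F)cc(C(F)(F)F)c1`: 3200 nM
compound 2 `COc1ccc(CNCCCNS(=O)(=O)c2cc(C(F)(F)F)cc(C(F)(F)F)c2)cc1OC`: 5300 nM
compound 3 `O=S(=O)(NCCCNCc1ccc(Cl)c(Cl)c1)c1cc(C(F)(F)F)cc(C(F)(F)F)c1`: 3000 nM

Compound 2 gives the highest of the three numbers, yet both of its steps stay within the scatter: a 1.7-fold higher number from compound 1 to compound 2 (0.22 log units; within the scatter) and a 1.8-fold lower number from compound 2 to compound 3 (0.25 log units; within the scatter). The remaining pair is likewise flat, a 1.1-fold lower number from compound 1 to compound 3 (0.03 log units; within the scatter). Compound 4 `COc1ccc(CNCCCNS(=O)(=O)c2cc(C(F)(F)F)cc(C(F)(F)F)c2)cc1` differs from compound 2 by hydrogen in place of methoxy on an aromatic carbon, that is, 3,4-dimethoxybenzyl to 4-methoxybenzyl. For the measured compounds named here, no measured step removes a single methoxy; the three steps exchange the whole aryl on the saturated chain carbon bound to the amine nitrogen, and none moves beyond the scatter. The expected step is therefore a 1.2-fold lower number from compound 2 to compound 4 (0.07 log units; within the scatter), none beyond the scatter. Compound 4 is estimated at 4500 nM, expected between 2200 nM and 9000 nM.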

Compound 4, concentration for 50% growth inhibition: 3100 nM
Beside the measured number, compound 4's estimate is 1.5-fold (0.16 log units) above it; measured number inside the range.
By their numbers in this assay, from the lowest: compounds 3, 4, 1 and 2 (each within the scatter of the next).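

In this assay, for the compounds shown here, the first step that changes one substituent on the aryl ring, with hydrogen in place of methoxy, gives a 1.7-fold lower number from compound 2 to compound 4 (0.23 log units; within the scatter). The whole-aryl exchanges give a 1.0-fold higher number from compound 3 to compound 4 (0.01 log units; within the scatter) and a 1.0-fold lower number from compound 1 to compound 4 (0.01 log units; within the scatter), so 4-methoxyphenyl is not separated from naphthalen-1-yl or 3,4-dichlorophenyl, and all steps among the four compounds stay within the scatter. Nothing shown here explains this flatness.

Still open, from the compounds shown here alone, is whether a carboxylic acid or an amine in place of the methoxy, or a longer chain in the linker, would give a step beyond the scatter.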